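From Ester to Alcohol in a Sigma Receptor Series

The source may report more compounds than this note shows. Statements on the series, on what has been measured and on what is new or still open speak of the compounds shown alone.

Compound 1 `COC(=O)C[C@@H]1Cc2ccccc2[C@H](CN2CCCCC2)O1` in an assay on membranes from brain for displacement of a labelled ligand from Sigma non-opioid intracellular receptor 1 (Cavia porcellus), read by scintillation counting, with a stated time of 2 h (on this read-out higher numbers stand for weaker inhibition and lower numbers for stronger inhibition), gives 510 nM. Compound 2 `COC(=O)C[C@@H]1Cc2ccccc2[C@H](CCN2CCCC2)O1` gives only a limit in this assay, > 1000 nM. Compound 3 `COC(=O)C[C@@H]1Cc2ccccc2[C@H](CCN2CCC(c3ccccc3)CC2)O1` gives 38 nM.

Among the two numbers, compound 3 has the lower one and compound 1 the higher; compound 2 contributes only its limit (the limit of > 1000 nM in this assay, at which 1 of the 3 values shown sits). Compound 4 `OCC[C@@H]1Cc2ccccc2[C@H](CCN2CCC(c3ccccc3)CC2)O1` differs from compound 3 by hydroxymethyl in place of methoxycarbonyl on a saturated chain carbon bound to a saturated ring carbon. For the measured compounds named here, the one measured step, an at least 1.9-fold higher number from compound 1 to compound 2 (0.29 log units; that floor lies within the scatter), concerns the amine part of the core and not this position, so no measured step bears on the change. The expected change from compound 3 to compound 4 is therefore a 1.8-fold higher number from compound 3 to compound 4 (0.27 log units; within the scatter), a modest weakening that may stay within the scatter. Compound 4 is expected to give 70 nM, between 20 nM and 250 nM.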

Compound 4, inhibition constant: 52 nM
For compound 4 the middle estimate is 1.3-fold (0.13 log units) above the measured one, within the range that was stated.
By their numbers in this assay, from the lowest: compounds 3 and 4 (each within the scatter of the next); then compound 1. At a limit, above all of these: compound 2.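

In this assay, this position now has its first measured step, and replacing methoxycarbonyl with hydroxymethyl gives a 1.4-fold higher number from compound 3 to compound 4 (0.14 log units; within the scatter). The methoxycarbonyl group and its carbonyl are therefore not required for a value in this range on the core of compound 3, and a smaller group carrying a hydrogen-bond donor is accepted there. Nothing in the data at hand accounts for this outcome. Going by these compounds, whether a carboxylic acid, an amine or a longer chain at this place would read the same remains open. So does whether the change carries over to the piperidin-1-yl side chain of compound 1.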